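Methoxy on the phenyl ring of an acrylamide thiazole

This account rests on a few compounds, and the source may have more. Where it says the series, first, only, none or still open, it means among the compounds named here.

The measured compounds:
- compound 1, `C=CC(=O)Nc1nc(-c2ccccc2)cs1`, gives 6600 nM in a functional assay on HT-29 cells (Homo sapiens) for antiproliferative activity, read by MTT assay, with a stated time of 72 h; a higher number here means a weaker inhibitor, a lower number a stronger inhibitor
- compound 2, `C=CC(=O)Nc1nc(-c2ccc(OC)cc2)cs1`, gives 12000 nM in this assay
- compound 3, `C=CC(=O)N(Cc1cc(C)no1)c1nc(-c2ccccc2)cs1`, gives only a limit, > 30000 nM, in this assay

Compound 1 and compound 2 differ by methoxy in place of hydrogen on an aromatic carbon, and this step is a 1.8-fold higher number from compound 1 to compound 2 (0.26 log units; within the scatter), so the two values cannot be told apart. Compound 1 and compound 3 differ in their core by (3-methyl-1,2-oxazol-5-yl)methyl in place of hydrogen on an amide-type nitrogen, and that step is an at least 4.5-fold higher number from compound 1 to compound 3 (0.65 log units; beyond the scatter). The value of compound 3 is a limit of the assay, not a number, as shown by the limit of > 30000 nM in this assay, at which 1 of the 3 values shown sits.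

Compound 4, `C=CC(=O)N(Cc1cc(C)no1)c1nc(-c2ccccc2OC)cs1`, is not yet measured. It differs from compound 3 by methoxy in place of hydrogen on an aromatic carbon. This is the same kind of change as between compound 1 and compound 2, but not the same: on compound 2 the methoxy sits para to a large group, while on compound 4 it sits ortho to a large group.

The expectation for compound 4 rests on compound 1 to compound 2, where the step was a 1.8-fold higher number from compound 1 to compound 2 (0.26 log units; within the scatter), and on compound 3 sitting at a limit. The step from compound 3 to compound 4 is therefore estimated as a step that the limit leaves unreadable from compound 3 to compound 4, small and probably again ending at a limit. Compound 4 is expected to give about 50000 nM, estimated between 20000 nM and 150000 nM, in this assay.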

Compound 4, half-maximal inhibitory concentration: > 30000 nM
Compound 4: no number, only a limit; the forecaster's own chance of this, stated with the estimate: 85%; the middle value does not contradict the limit.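

Among the compounds shown here, compound 3 and compound 4 both end at a limit of the assay rather than at a number, so no step between them can be read: the limit of > 30000 nM in this assay, at which 2 of the 4 values shown sit. The compounds shown leave open what the true values of compound 3 and compound 4 are, and whether methoxy on the phenyl ring makes any difference once (3-methyl-1,2-oxazol-5-yl)methyl sits on the amide-type nitrogen.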